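This account rests on a few compounds, and the source may have more. Where it says the series, first, only, none or still open, it means among the compounds named here.

Measured in a functional assay on HEY cells (Homo sapiens) for cytotoxicity, read by MTT assay, with a stated time of 72 h (on this read-out higher numbers stand for weaker inhibition and lower numbers for stronger inhibition), so far:
compound 1 `N[C@H]1CC[C@H](Nc2c(C(=O)NCc3ccco3)nc(Br)c3cccnc23)CC1` gives > 10000 nM (a limit)
compound 2 `N[C@H]1CC[C@H](Nc2c(C(=O)NCc3ccc(F)cc3)nc(Br)c3cccnc23)CC1` gives "not determined" (no result reported) (no number)
compound 3 `N[C@H]1CC[C@H](Nc2c(C(=O)NCc3ccccn3)nc(Br)c3cccnc23)CC1` gives > 20000 nM (a limit)

Compound 3 thus offers no exact number, only a limit. Within the data shown here, compound 1 is likewise held by a limit, and compound 2 has no result, so no compound in this set has a readable potency.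

The next compound is compound 4 `N[C@H]1CC[C@H](Nc2c(C(=O)NCc3ccccc3)nc(Br)c3cccnc23)CC1`, which differs from compound 3 as follows: phenyl in place of pyridin-2-yl on a saturated chain carbon bound to an amide-type nitrogen. In words, this is phenyl in place of pyridin-2-yl on a saturated chain carbon bound to an amide-type nitrogen.

Among the measured compounds shown here, the only measured step at this place is a step that the two limits leave unreadable from compound 1 to compound 3, so it gives no size to carry over. Nothing measured points to a gain or a loss, and weak inhibition is expected to persist in this assay as a result.

The estimated step is a number no higher from compound 3 to compound 4 (the limit leaves the size open) and no change beyond the scatter is expected. For compound 4 the estimate is 20000 nM with an expected range from 8000 nM to 40000 nM and a report of only a limit is quite likely.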

Compound 4, half-maximal inhibitory concentration: 8000 nM
Estimate against measurement, compound 4: 2.5-fold (0.40 log units) above; low and high end bracket the measured number.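

In this assay compound 4 gives 8000 nM, the only exact number among the compounds shown, so a change on the saturated chain carbon bound to an amide-type nitrogen can now be tied to a measured value. Phenyl in place of pyridin-2-yl brings an at least 2.5-fold lower number from compound 3 to compound 4 (0.39 log units; beyond the scatter), and this size is only a floor, with compound 3 held by a limit: the limit of > 20000 nM in this assay, at which 1 of the 4 values shown sits. Phenyl in place of furan-2-yl brings an at least 1.2-fold lower number from compound 1 to compound 4 (0.09 log units; that floor lies within the scatter), which leaves the true size of this step open, with compound 1 also held by a limit: the limit of > 10000 nM in this assay, at which 1 of the 4 values shown sits.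

Going by these compounds, compound 2, which carries fluorine on the benzyl ring, has no reported result, so the effect of a substituent on that phenyl ring remains unknown. Also open, on these data alone, is how a longer chain such as 2-phenylethyl would compare with the benzyl group of compound 4.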